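Nitro for trifluoromethyl on the shared core

The source may hold more compounds than are shown below. What is called first, only, known or untested is meant among the compounds shown, and "the series" means these compounds.

Among the measured compounds shown here, compound 1 `COc1ccc(-c2nc3cc(C(F)(F)F)ccc3[nH]2)c(OC)c1OC` is the one member of the series with an actual number in an ADME assay on Vero cells (Chlorocebus sabaeus) for cytotoxicity; a higher number here means that more compound is tolerated, a lower number that less compound is tolerated: compound 1 gives 70000 nM. Compound 2 `COc1ccc(-c2nc3cc(C(F)(F)F)ccc3[nH]2)c(OC)c1` differs from compound 1 only by hydrogen in place of methoxy on an aromatic carbon; in this assay compound 2 reaches only a limit, > 100000 nM. Compound 3 `C#C[C@@]1(O)[C@H](O)[C@@H](CO)O[C@H]1n1ccc(N)nc1=O`, unrelated in structure, likewise reaches only a limit in this assay, > 100000 nM. For the measured compounds named here, the single measured step, an at least 1.4-fold higher number from compound 1 to compound 2 (0.15 log units; that floor lies within the scatter), rests on that limit; the floor it sets lies within the scatter, so it says little about the size of any change, and the limit of > 100000 nM in this assay, at which 2 of the 3 values shown sit, shows how much of the series sits at that limit.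

Compound 4 `COc1ccc(-c2nc3cc([N+](=O)[O-])ccc3[nH]2)c(OC)c1OC` departs from compound 1 by nitro in place of trifluoromethyl on an aromatic carbon. Going by the values given here, no measured step in this assay concerns the trifluoromethyl or the nitro group, and the one measured step touches a different position; it therefore gives no direction for this change. Compound 1 already sits close to the limit, so the expected step of a 1.1-fold higher number from compound 1 to compound 4 (0.03 log units; within the scatter) is none beyond the scatter. Compound 4 is accordingly estimated at 75000 nM, with a range from 30000 nM to 100000 nM, and a real chance that only a limit is reported.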

Compound 4, half-maximal cytotoxic concentration: > 100000 nM
Compound 4: no number, only a limit; the forecaster's own chance of this, stated with the estimate: 40%; middle value at least 1.3-fold (0.12 log units) away from the limit.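

Nitro in place of trifluoromethyl is the first change at this position of the shared core with a reading in this assay, and it gives an at least 1.4-fold higher number from compound 1 to compound 4 (0.15 log units; that floor lies within the scatter). The value of compound 4 is a limit, so the step sets only a floor and gives no size for the change. Even so, the trifluoromethyl group is not needed for the number to stay clear of a drop from compound 1, and the series now rests mostly on limits: the limit of > 100000 nM in this assay, at which 3 of the 4 values shown sit.

Still open, from the compounds shown here alone, is how an amine or a carboxylic acid on this aromatic carbon would read in this assay, and whether any group here lowers the number beyond the scatter. Also open, going by these compounds, is how the nitro change and the loss of a methoxy group act together, since compound 2 and compound 4 differ in more than one place and each alone offers only a limit.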